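The compounds below may be only part of what the source reports. "The series", "measured", "known", "first", "only" and "open" are said of these compounds alone.

Measured compounds:
- compound 1, `CC1(C)Cc2c(sc(NC(=O)Cc3ccn[nH]3)c2C(N)=O)C(C)(C)O1`: 136 nM
- compound 2, `CC1(C)Cc2c(sc(NC(=O)C3(CO)CC3)c2C(N)=O)C(C)(C)O1`: 15 nM
- compound 3, `CC1(C)Cc2c(sc(NC(=O)C(C)(C)CO)c2C(N)=O)C(C)(C)O1`: 75 nM

In an assay on cells for positive allosteric modulation of Cystic fibrosis transmembrane conductance regulator variant F508del (Homo sapiens), with stated times of 10 min and 7 s, in the presence of a further agent that is not named here (on this read-out higher numbers stand for an effect only at larger amounts of compound and lower numbers for an effect already at smaller amounts), compound 1 gives the highest of the three numbers. Compound 3 stands closest to it, and that gap (a 1.8-fold lower number from compound 1 to compound 3 (0.26 log units; within the scatter)) lies within the scatter. Compound 2 is furthest from it: a 9.1-fold lower number from compound 1 to compound 2 (0.96 log units; beyond the scatter), a step beyond the scatter. Between compound 2 and compound 3 the gap is a 5.0-fold higher number from compound 2 to compound 3 (0.70 log units; beyond the scatter).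

Compound 4, `Cc1cn[nH]c1C(=O)Nc1sc2c(c1C(N)=O)CC(C)(C)OC2(C)C`, differs from compound 1 by 4-methyl-1H-pyrazol-5-yl in place of (1H-pyrazol-5-yl)methyl on a carbonyl carbon. For the measured compounds named here, none of the measured steps bears directly on this change: both steps from compound 1 swap the (1H-pyrazol-5-yl)methyl for a saturated hydroxymethyl-bearing group, and both move the number downward, one beyond the scatter (a 9.1-fold lower number from compound 1 to compound 2 (0.96 log units; beyond the scatter)), one within it (a 1.8-fold lower number from compound 1 to compound 3 (0.26 log units; within the scatter)). Going by the values given here, the data hold no pair in which the pyrazole is kept and only its attachment or a ring methyl changes. The expectation therefore rests on compound 1 as the anchor, with a wide range allowing for a shift in either direction. For compound 4 the expected step is a 1.9-fold lower number from compound 1 to compound 4 (0.29 log units; within the scatter), and its estimated value in this assay is 70 nM, between 15 nM and 300 nM.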

Compound 4, half-maximal effective concentration: 2 nM
For compound 4 the middle estimate is 35-fold (1.54 log units) above the measured one, and the stated range ends above it.
By their numbers in this assay, from the lowest: compound 4; then compound 2; then compounds 3 and 1 (each within the scatter of the next).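

In this assay, the two pyrazole-bearing groups on the carbonyl carbon contain the same atoms joined differently, yet the change from (1H-pyrazol-5-yl)methyl to 4-methyl-1H-pyrazol-5-yl gives a large step (a 68-fold lower number from compound 1 to compound 4 (1.83 log units; beyond the scatter)), so the counts printed for the two groups do not settle the outcome at this position. The aromatic group also passes both saturated hydroxymethyl-bearing groups (a 38-fold lower number from compound 3 to compound 4 (1.57 log units; beyond the scatter); a 7.5-fold lower number from compound 2 to compound 4 (0.88 log units; beyond the scatter)), which places compound 4 at the low end of the series and leaves compound 2 no longer the lowest number. No supporting measurement accounts for this step.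

Direct attachment of the ring and its methyl group remain inseparable here; 1H-pyrazol-5-yl without the methyl would divide the two contributions. Also open, on these data alone, is whether 4-ethyl-1H-pyrazol-5-yl or 4-chloro-1H-pyrazol-5-yl would keep the number this low.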